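Extending the ether chain of compound 1 toward an aryl group

This account rests on a few compounds, and the source may have more. Where it says the series, first, only, none or still open, it means among the compounds named here.

Compound 1 `C/C=C/COc1cc(/C=C\c2cc(OC)c(OC)c(OC)c2)ccc1OC` stands highest of the three numbers in an ADME assay on HEK293 cells (Homo sapiens) for inhibition, read by MTT assay, with a stated time of 3 days (on this read-out higher numbers stand for weaker inhibition and lower numbers for stronger inhibition), where compound 1 gives 135000 nM. Compound 2 `COc1ccc(/C=C\c2cc(OC)c(OC)c(OC)c2)cc1OCc1ccccc1` gives 15000 nM in this assay, and compound 3 `COCOc1ccc(/C=C/CCCOc2cc(/C=C\c3cc(OC)c(OC)c(OC)c3)ccc2OC)cc1` gives 25000 nM. Compound 4 `COc1ccc(/C=C\c2cc(OC)c(OC)c(OC)c2)cc1OCCC/C=C/c1ccc(Br)cc1` differs from compound 1 at a single place: a group of 11 heavy atoms (10 carbon, 1 bromine; one six-membered aromatic ring of carbon only) in place of a group of 3 heavy atoms (3 carbon; no ring), on a saturated chain carbon bound to an oxygen on an aromatic ring. The step that bears on this change is a 9.0-fold lower number from compound 1 to compound 2 (0.95 log units; beyond the scatter), where a ring also entered at that same place, and compound 3, which likewise carries a longer chain ending in an aromatic ring, sits below compound 1. A lower number is therefore expected for compound 4, by a step of about a 5.4-fold lower number from compound 1 to compound 4 (0.73 log units; beyond the scatter). In this assay compound 4 is estimated at 25000 nM, within a range from 6000 nM to 80000 nM.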

Compound 4, half-maximal inhibitory concentration: 55000 nM
Estimate against measurement, compound 4: 2.2-fold (0.34 log units) below; the range from low to high includes it.
By their numbers in this assay, from the lowest: compounds 2 and 3 (each within the scatter of the next); then compound 4; then compound 1.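

In this assay, the ring-bearing group of 11 heavy atoms still lowers the number at this saturated chain carbon, with a 2.5-fold lower number from compound 1 to compound 4 (0.39 log units; beyond the scatter), but the benzyl-type ether stays lower, with a 3.7-fold higher number from compound 2 to compound 4 (0.56 log units; beyond the scatter), so a ring arriving at this place does not alone set the value. The far end of the chain also counts, as bromo in place of methoxymethoxy on an aromatic carbon gives a 2.2-fold higher number from compound 3 to compound 4 (0.34 log units; beyond the scatter). Nothing available explains these differences. On these data alone, whether an amine or a carboxylic acid on that aromatic carbon, or a longer chain, would lower the number further remains open.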